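The source may hold more compounds than are shown below. What is called first, only, known or untested is meant among the compounds shown, and "the series" means these compounds.

In an ADME assay on liver for metabolic stability, with Liver microsome (Rattus norvegicus) as the target, using microsomes and NADPH, with a stated time of 30 min, tested at 0.5 uM (on this read-out lower numbers stand for slow clearance and higher numbers for fast clearance), compound 1 `O=c1[nH]ccn1CCOc1nn(-c2ccccc2F)c2ccc(F)cc12` gives 783 mL/min/kg and compound 2 `CC(Oc1nn(-c2ccccc2F)c2ccc(F)cc12)C(=O)N1CCOCC1` gives 717 mL/min/kg. Compound 3 `O=C1N(c2ccncc2)CCN1c1cccc2c1cnn2-c1ccccc1F` gives 228 mL/min/kg, the lowest of the three numbers and clearly apart from both others, beyond the usual scatter. Compound 4 `O=C1N(Cc2ncco2)CCN1c1cccc2c1cnn2-c1ccccc1F` has not been measured yet. It keeps the core of compound 3 but carries (1,3-oxazol-2-yl)methyl in place of pyridin-4-yl on an amide-type nitrogen in a ring. Among the measured compounds shown here, no measured pair differs in one place only, so no earlier step guides this change. Compound 3, at 228 mL/min/kg, is the closest measured relative, so only a small rise within the scatter is expected. The expected step is a 1.3-fold higher number from compound 3 to compound 4 (0.12 log units; within the scatter). For compound 4 the estimate is 300 mL/min/kg, with an expected range of 130 mL/min/kg to 650 mL/min/kg.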

Compound 4, clearance: 100 mL/min/kg
For compound 4 the middle estimate is 3.0-fold (0.48 log units) above the measured one, and the stated range ends above it.
By their numbers in this assay, from the lowest: compound 4; then compound 3; then compounds 2 and 1 (each within the scatter of the next).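

At the amide-type nitrogen in a ring, the group strongly shapes the result: in this assay, replacing pyridin-4-yl with (1,3-oxazol-2-yl)methyl gives a 2.3-fold lower number from compound 3 to compound 4 (0.36 log units; beyond the scatter), even though both groups have the same heavy-atom count. This is the only single-place comparison shown, so it is the first direct sign that this position affects clearance. No measured evidence here explains the step.

A benzyl or pyridin-4-ylmethyl group at this position could help separate the contribution of the new ring from that of the added carbon link. As far as these compounds go, whether the same swap would lower clearance on another core remains open.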